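Moving the Methoxy Group on a Benzyloxy Chalcone

This account rests on a few compounds, and the source may have more. Where it says the series, first, only, none or still open, it means among the compounds named here.

The shared core is seen in compound 1 `O=C(/C=C/c1ccccc1Cl)c1ccc(OCc2ccccc2)cc1`, which in a functional assay on HCT-116 cells (Homo sapiens) for antiproliferative activity, read by sulforhodamine B assay, with a stated time of 3 days, tested at 50 uM (on this read-out higher numbers stand for a stronger effect at the one concentration tested and lower numbers for a weaker effect), gives 99.7%. Compound 2 `O=C(/C=C/c1ccc(F)cc1)c1ccc(OCc2ccccc2)cc1` has in this assay the entry "not determined" (no result reported), so no number stands for it. Compound 3 `COc1cccc(/C=C/C(=O)c2ccc(OCc3ccccc3)cc2)c1` gives 76% in this assay, the lowest of the two numbers shown, with compound 1 the nearest entry. Among the measured compounds shown here, the one measured step is a number 23.7 percentage points lower from compound 1 to compound 3 (beyond the scatter), and it exchanges one aryl group for a quite different one, so it bears only loosely on the change at hand. Compound 4 `COc1ccc(/C=C/C(=O)c2ccc(OCc3ccccc3)cc2)cc1` differs from compound 3 by 4-methoxyphenyl in place of 3-methoxyphenyl on a double-bonded chain carbon bound to a double-bonded chain carbon. For the measured compounds named here, with no closely related step known, no change beyond the scatter is expected, a number 4 percentage points lower from compound 3 to compound 4 (within the scatter). Compound 4 is therefore estimated at 72%, with a range from 45% to 95%.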

Compound 4, a percentage reported as inhibition, at one concentration (the size of the read-out at that concentration, not a potency): 13.2%
For compound 4 the middle estimate is 58.8 percentage points above the measured one; the measured number lies below the stated range.
By their numbers in this assay, from the lowest: compound 4; then compound 3; then compound 1.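

Moving the methoxy group, with the same atoms joined differently, is far from neutral in this assay: the change gives a number 62.8 percentage points lower from compound 3 to compound 4 (beyond the scatter) at this position on the double-bonded chain carbon. The 4-methoxyphenyl group also compares poorly with the 2-chlorophenyl group, giving a number 86.5 percentage points lower from compound 1 to compound 4 (beyond the scatter) in the same place. Nothing available here accounts for this sensitivity to where the methoxy group sits. Still open, going by these compounds, is how a 2-methoxyphenyl group or an aminophenyl group would fare in this place, and whether the drop seen with the 4-methoxyphenyl group extends to other groups there.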